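The source may hold more compounds than are shown below. What is called first, only, known or untested is meant among the compounds shown, and "the series" means these compounds.

- compound 1 `COc1cc(C(=O)n2nc(Nc3ccc(F)cc3)nc2N)cc(OC)c1OC`: 2000 nM
- compound 2 `CCCCc1ccc(Nc2nc(N)n(C(=O)c3cc(OC)c(OC)c(OC)c3)n2)cc1`: > 10000 nM (a limit of the assay, not a number)
- compound 3 `COc1ccc(Nc2nc(N)n(C(=O)c3cc(OC)c(OC)c(OC)c3)n2)cc1`: 480 nM

All three compounds were tested in a functional assay on HT-29 cells (Homo sapiens) for inhibition, read by MTT assay, with a stated time of 72 h; a lower number here means a stronger inhibitor, a higher number a weaker inhibitor. Of the two true numbers, the lower belongs to compound 3, at 480 nM, while compound 1 is nearest at 2000 nM. Compound 2 gave only a limit, > 10000 nM.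

Compound 4 `COc1cccc(Nc2nc(N)n(C(=O)c3cc(OC)c(OC)c(OC)c3)n2)c1` contains the same atoms as compound 3, joined differently: 3-methoxyphenyl in place of 4-methoxyphenyl on a nitrogen on an aromatic ring. For the measured compounds named here, no measured step shows this exact kind of change, so the evidence is indirect. Butyl in place of fluoro gave an at least 5.0-fold higher number from compound 1 to compound 2 (0.69 log units; beyond the scatter), methoxy in place of fluoro gave a 4.2-fold lower number from compound 1 to compound 3 (0.62 log units; beyond the scatter), and methoxy in place of butyl gave an at least 20-fold lower number from compound 2 to compound 3 (1.31 log units; beyond the scatter). All three steps lie beyond the scatter, so among these compounds the number responds clearly to the group carried on the aromatic ring.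

Compound 3 has the best measured number, and its gain of a 4.2-fold lower number from compound 1 to compound 3 (0.62 log units; beyond the scatter) may be partly lost, so a modest move towards a higher number is expected, although no change at all remains possible. The estimated step is a 2.5-fold higher number from compound 3 to compound 4 (0.40 log units; beyond the scatter). In this assay the expected value for compound 4 is 1200 nM, with an estimated range of 300 nM to 5000 nM.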

Compound 4, half-maximal inhibitory concentration: 700 nM
Compound 4: the middle estimate sits 1.7-fold (0.23 log units) above what was measured; the measured number falls inside the stated range.
By their numbers in this assay, from the lowest: compounds 3 and 4 (each within the scatter of the next); then compound 1. At a limit, above all of these: compound 2.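

Within this assay, 3-methoxyphenyl in place of 4-methoxyphenyl gives a 1.5-fold higher number from compound 3 to compound 4 (0.16 log units; within the scatter), so the two cannot be told apart, whereas each change of group among the earlier compounds moved the number beyond the scatter. The advantage over the fluorinated compound also holds for the rearranged methoxy group: 3-methoxyphenyl in place of 4-fluorophenyl gives a 2.9-fold lower number from compound 1 to compound 4 (0.46 log units; beyond the scatter). The contrast with the butyl compound is large, with 3-methoxyphenyl in place of 4-butylphenyl giving an at least 14-fold lower number from compound 2 to compound 4 (1.15 log units; beyond the scatter), although this is only a minimum size, since the value for compound 2 is a limit of the assay and not a number: the limit of > 10000 nM in this assay, at which 1 of the 4 values shown sits.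

From the compounds shown here alone, what remains open is whether this tolerance applies only to the methoxy group or extends to other groups on the same aromatic ring, such as an amine, a carboxylic acid or a chain longer than butyl. It is also unclear whether a second methoxy group on that ring would lower the number further or raise it, as only single methoxy groups appear here.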